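The source may hold more compounds than are shown below. What is called first, only, known or untested is meant among the compounds shown, and "the series" means these compounds.

Working notes on the series; all numbers below come from an assay for inhibition of Aromatase (Homo sapiens); on this read-out higher numbers stand for weaker inhibition and lower numbers for stronger inhibition.

compound 1 `O=c1c(-c2ccccc2)c(-n2ccnc2)oc2cc(OCc3ccccc3)ccc12`: 520 nM
compound 2 `COc1ccc(-c2c(-n3ccnc3)oc3cc(OCc4ccccc4)ccc3c2=O)cc1`: 4700 nM
compound 3 `COc1ccc2c(=O)c(-c3ccccc3)c(-n3cncn3)oc2c1`: 18000 nM

On these numbers compound 3 stands highest of the three, with compound 2 its nearest neighbour and compound 1 the furthest; both gaps are beyond the scatter. Within the data shown here, the one step measured, a 9.0-fold higher number from compound 1 to compound 2 (0.96 log units; beyond the scatter), concerns a methoxy added on an aromatic carbon and does not touch the ring that sits next to the ring oxygen. Compound 4, `COc1ccc2c(=O)c(-c3ccccc3)c(Sc3nnc[nH]3)oc2c1`, differs from compound 3 by (4H-1,2,4-triazol-3-yl)sulfanyl in place of 1H-1,2,4-triazol-1-yl on an aromatic carbon. Among the measured compounds shown here, no measured step in this assay bears on this change. Compounds 1 and 2 carry an imidazolyl group where compound 3 carries its triazolyl, but they differ from compound 3 in more than one place, so their values show only that the series spans a wide range. With nothing to lean on, the expectation for compound 4 in this assay is an estimated step of a 1.4-fold higher number from compound 3 to compound 4 (0.14 log units; within the scatter), small against the uncertainty, the number expected to stay near the high end of the series. Compound 4 is therefore estimated at 25000 nM, with a range from 8000 nM to 80000 nM.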

Compound 4, half-maximal inhibitory concentration: > 50000 nM
Compound 4 gave a limit, no number; the forecaster's own chance of this, stated with the estimate: 25%; middle value at least 2.0-fold (0.30 log units) away from the limit.
By their numbers in this assay, from the lowest: compound 1; then compound 2; then compound 3. At a limit, above all of these: compound 4.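

In this assay compound 4 gives > 50000 nM, which is a limit of the assay and not a number. Among these compounds, replacing 1H-1,2,4-triazol-1-yl with (4H-1,2,4-triazol-3-yl)sulfanyl on the aromatic carbon next to the ring oxygen gives an at least 2.7-fold higher number from compound 3 to compound 4 (0.44 log units; beyond the scatter), the first measured step at this position, and it shows that the read-out responds to a change of group here, by an amount beyond the scatter. Compound 4 is the only compound of the series whose reading is a limit: the limit of > 50000 nM in this assay, at which 1 of the 4 values shown sits.

The change brings in several differences at once, namely the sulfur link, attachment of the triazole through a ring carbon rather than a ring nitrogen, and one hydrogen-bond donor, so the compounds shown leave open which of these accounts for the step, and how far it extends past the limit. Also open, going by these compounds, is how this position would read with an amine or a methylsulfanyl group, and whether the same change would give a similar step on the benzyloxy-bearing core of compound 1.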